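A few compounds are considered here, and "the series" means these few. Any claim that something is new, unique, unknown or untested is made for them only; others in the source may bear on it.

In an assay on cell membranes for displacement of a labelled ligand from Neuronal acetylcholine receptor; alpha4/beta2 (Rattus norvegicus), read by scintillation counting, with a stated time of 2 h, tested at 5 uM (on this read-out lower numbers stand for less inhibition and higher numbers for more inhibition at the one concentration tested (going by the name of the read-out)), compound 1 `O=C1CC(c2ccccc2)=NCC2(CN3CCC2CC3)N1` gives 15%, compound 2 `O=C1CC(c2ccc(Br)s2)=NCC2(CN3CCC2CC3)N1` gives 62% and compound 3 `O=C1CC(c2cccs2)=NCC2(CN3CCC2CC3)N1` gives 20%. Compound 3 stands second highest of the three numbers: its nearest neighbour lies within the scatter, a number 5 percentage points higher from compound 1 to compound 3 (within the scatter), and its furthest lies well beyond it, a number 42 percentage points lower from compound 2 to compound 3 (beyond the scatter). Compound 4 `O=C1CC(c2ccco2)=NCC2(CN3CCC2CC3)N1` has not yet been measured and differs from compound 3 in one place: furan-2-yl in place of thiophen-2-yl on a carbon with a double bond to nitrogen. Of the measured steps, that from compound 1 to compound 3 is the closer parallel, a swap of one aromatic ring for another on the same carbon that stayed within the scatter; the bromo step concerns a substituent and bears less. Compound 4 is therefore expected to show a number 2 percentage points lower from compound 3 to compound 4 (within the scatter). Compound 4 is estimated at 18%, from 5% to 35%.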

Compound 4, a percentage reported as inhibition, at one concentration (the size of the read-out at that concentration, not a potency): 14%
Compound 4: the middle estimate sits 4 percentage points above what was measured; the range from low to high includes it.
By their numbers in this assay, from the lowest: compounds 4, 1 and 3 (each within the scatter of the next); then compound 2.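

In this assay the ring itself proves interchangeable at this carbon with a double bond to nitrogen: there is a number 6 percentage points lower from compound 3 to compound 4 (within the scatter) and a number 1 percentage points lower from compound 1 to compound 4 (within the scatter), so furan-2-yl cannot be told apart from thiophen-2-yl or phenyl. Only the bromo-bearing ring stands apart, with a number 48 percentage points lower from compound 2 to compound 4 (beyond the scatter). No measurement here explains these readings. Open, from the compounds shown here alone, is whether a bromo group on furan-2-yl would raise the number as it does on thiophen-2-yl, and whether a chloro or methoxy group could replace that bromo.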